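The source may hold more compounds than are shown below. What is called first, only, known or untested is meant among the compounds shown, and "the series" means these compounds.

Compound 1 `O=C(N1CCCCC1COc1ccc(F)cc1)n1ncc(C(O)(c2ccccc2)c2ccccc2)n1` was tested in an assay on isolated protein for inhibition of Monoacylglycerol lipase ABHD6 (Homo sapiens), read by fluorescence (on this read-out lower numbers stand for stronger inhibition and higher numbers for weaker inhibition), and gave 251 nM. Two related compounds set the frame. Compound 2 `COc1ccc(CC2CCCCN2C(=O)n2ncc(C(O)(c3ccc(F)cc3)c3ccc(F)cc3)n2)cc1` gives 251 nM, level with compound 1 at the digits shown, so no difference between the two can be read. Compound 3 `O=C(N1CCCCC1Cc1ccccc1)n1ncc(C(O)(c2ccc(F)cc2)c2ccc(F)cc2)n1` gives 25.1 nM; against it, compound 1 and compound 2 together hold the highest numbers of the three. For the measured compounds named here, the one change measured between neighbouring structures, a 10-fold lower number from compound 2 to compound 3 (1.00 log units; beyond the scatter), takes a methoxy group off an aromatic carbon. Compound 4 `O=C(N1CCCCC1COc1ccccc1)n1ncc(C(O)(c2ccccc2)c2ccccc2)n1` differs from compound 1 by a change of the same general kind, (hydrogen in place of fluoro on an aromatic carbon), which read one bond further out is 4-fluorophenoxy becoming phenoxy. Going by the values given here, no measured pair shows exactly this change, and the methoxy step from compound 2 to compound 3 concerns a different group, so it guides only loosely. The most likely outcome is a small step or none beyond the scatter, with a slight lean toward a lower number. For compound 4 the expected result is 160 nM, within a range from 60 nM to 500 nM. This estimate for compound 4 amounts to a 1.6-fold lower number from compound 1 to compound 4 (0.20 log units; within the scatter).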

Compound 4, half-maximal inhibitory concentration: 158 nM
The estimate for compound 4 lay 1.0-fold (0.01 log units) above the measured number; measured number inside the range.
By their numbers in this assay, from the lowest: compound 3; then compounds 4, 1 and 2 (each within the scatter of the next).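

Replacing the fluoro of the 4-fluorophenoxy group with hydrogen, on an aromatic carbon para to a large group, gives a 1.6-fold lower number from compound 1 to compound 4 (0.20 log units; within the scatter) in this assay, so this pair shows no difference that can be told apart from ordinary repeat variation. The earlier step, a 10-fold lower number from compound 2 to compound 3 (1.00 log units; beyond the scatter), had shown that taking a methoxy group off an aromatic carbon can matter in another compound pair, whereas here the fluoro can be removed with no readable effect on the number, at this position and with the rest of compound 1 unchanged. Nothing shown here offers an explanation for this result.

The compounds shown leave open whether a chloro, a nitrile or a trifluoromethyl group in this same place on the phenoxy group would also leave the number within the scatter or move it clearly. On these data alone, it also remains open whether the fluoro groups on the two phenyl rings of compound 3 contribute to its value, since the fluoro examined here sits on a different part of the molecule.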